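Working notes: from compound 1 to compound 3

The source may hold more compounds than are shown below. What is called first, only, known or untested is meant among the compounds shown, and "the series" means these compounds.

- compound 1 `CS(=O)(=O)NC(=O)CCc1cn(-c2ccc(Cl)cc2)nc1-c1ccc(Cl)cc1` at 100000 nM
- compound 2 `C[S+]([O-])c1ccc(-n2cc(CCC(=O)NS(C)(=O)=O)c(-c3ccc(Cl)cc3)n2)cc1` at 200000 nM

For the measured compounds named here, in a physicochemical assay for solubility, in phosphate buffer, measured as thermodynamic solubility, at pH 7.4 (a higher number here means a more soluble compound, a lower number a less soluble compound), compound 1 at 100000 nM stands within the scatter of compound 2, the only other measured compound. Compound 3 `CS(=O)(=O)NC(=O)CCc1cn(-c2ccc(Cl)cc2)nc1-c1ccccc1Cl` is reached from compound 1 through 2-chlorophenyl in place of 4-chlorophenyl on an aromatic carbon and keeps the same atoms, joined differently. Going by the values given here, the one measured step of a 2.0-fold higher number from compound 1 to compound 2 (0.30 log units; within the scatter) is a different change and stays within the scatter. Among the compounds with values here, no measured step moves a chlorine around its ring, so the evidence is thin. In this assay the expected step of a 1.3-fold higher number from compound 1 to compound 3 (0.11 log units; within the scatter) is estimated as nothing beyond the scatter. Compound 3 is estimated at 130000 nM with an expected range of 50000 nM to 300000 nM for now.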

Compound 3, solubility: 90000 nM
The estimate for compound 3 lay 1.4-fold (0.16 log units) above the measured number, within the range that was stated.
By their numbers in this assay, from the lowest: compounds 3, 1 and 2 (each within the scatter of the next, the first and the last beyond it).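

In this assay, for the compounds shown here, 2-chlorophenyl in place of 4-chlorophenyl on the aromatic carbon next to the ring nitrogen gives a 1.1-fold lower number from compound 1 to compound 3 (0.05 log units; within the scatter) and is the first measured step at this position. At this position, the two chlorophenyl groups are not separated beyond the scatter, unlike what a change of chlorine placement might have shown. No measurement at hand explains this result.

Still open, on these data alone, is whether an amine or a carboxylic acid in place of the chlorine on this phenyl ring would shift the number beyond the scatter. Also open, as far as these compounds go, is whether the same holds for either group on the other chlorophenyl ring of the shared core.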